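This account rests on a few compounds, and the source may have more. Where it says the series, first, only, none or still open, it means among the compounds named here.

Measured so far in a functional assay on MDA-MB-231 cells (Homo sapiens) for cytotoxicity, read by MTT assay, with a stated time of 68 h; on this read-out lower numbers stand for stronger inhibition and higher numbers for weaker inhibition:
- compound 1 `O=C(/C=C/c1cccc(OCc2ccccc2)c1)c1ccc(Br)cc1`: 6400 nM
- compound 2 `O=C(/C=C/c1cccc(OCc2ccccc2)c1)c1ccc(Cl)cc1`: 21500 nM

Of these two compounds, compound 2 stands higher at 21500 nM, so it is the less potent of the pair. The next compound to be tested, compound 3 `O=C(/C=C/c1cccc(OCc2ccccc2)c1)c1ccccc1`, has hydrogen in place of chloro on an aromatic carbon. The 4-chlorophenyl group thus becomes phenyl, and the rest of the structure stays the same.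

Among the compounds with values here, only one measured step bears on this change: a 3.4-fold higher number from compound 1 to compound 2 (0.53 log units; beyond the scatter). That step, chloro in place of bromo, is modest but beyond the scatter. Within the data shown here, it is only indirect evidence, since no measured compound yet lacks a halogen on this ring. Removing the halogen altogether might continue the same upward direction, but one step cannot establish a trend, so only a small rise in this assay is expected, probably no larger than the earlier step and possibly within the scatter. The expected step is a 1.3-fold higher number from compound 2 to compound 3 (0.11 log units; within the scatter). For compound 3 the estimated value is 28000 nM, with an expected range of 10000 nM to 80000 nM.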

Compound 3, half-maximal inhibitory concentration: 20000 nM
The estimate for compound 3 lay 1.4-fold (0.15 log units) above the measured number; the range from low to high includes it.
By their numbers in this assay, from the lowest: compound 1; then compounds 3 and 2 (each within the scatter of the next).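

In this assay, hydrogen in place of chloro on the 4-chlorophenyl group gives a 1.1-fold lower number from compound 2 to compound 3 (0.03 log units; within the scatter) and so leaves the number within the scatter, which means that at this place, para to a large group, compound 2 and compound 3 cannot be told apart. Hydrogen in place of bromo gives a 3.1-fold higher number from compound 1 to compound 3 (0.49 log units; beyond the scatter) in the same assay, a step beyond the scatter and of about the same size as a 3.4-fold higher number from compound 1 to compound 2 (0.53 log units; beyond the scatter) in the earlier pair, so among these three compounds only the bromo compound stands apart, with the lower number, and the earlier step no longer reads as the start of a graded series running from bromo through chloro to hydrogen. Nothing available explains why bromo differs here while chloro does not. What the compounds shown leave open is whether the lower number goes with bromo alone or would also appear with iodo, methyl, methoxy or trifluoromethyl at the same place. They also leave open how an amine or a carboxylic acid would read there, and whether bromo would give the same result elsewhere on this ring.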